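Swapping the Side Group on a Fast-Cleared Core

A few compounds are considered here, and "the series" means these few. Any claim that something is new, unique, unknown or untested is made for them only; others in the source may bear on it.

Compound 2 `CC(=O)N1CCC(c2cnc(NCc3c(F)ccc4c3CCO4)c3cn[nH]c(=O)c23)CC1` is one of two compounds tested in an ADME assay on microsomes from liver (Homo sapiens) for metabolic stability, read by LC-MS, using NADPH, with stated times of 5 min and 30 min, tested at 1 uM; on this read-out lower numbers stand for slow clearance and higher numbers for fast clearance; there compound 2 gives 207 mL.min-1.g-1, the higher of the two numbers. Compound 1 `O=C1c2ccccc2CN1c1cnc(NCc2c(F)ccc3c2CCO3)n2cnnc12` gives 13 mL.min-1.g-1 in this assay, a gap well beyond the usual scatter. Compound 3 `Cc1nn(C)cc1-c1cnc(NCc2c(F)ccc3c2CCO3)c2cn[nH]c(=O)c12` differs from compound 2 in one place: 1,3-dimethyl-1H-pyrazol-4-yl in place of 1-acetylpiperidin-4-yl on an aromatic carbon. Because compound 2 starts from 207 mL.min-1.g-1, a move towards slower clearance seems somewhat more likely than a further rise, though two measured compounds give little to go on. The step expected from this change is modest, a 1.7-fold lower number from compound 2 to compound 3 (0.24 log units; within the scatter). Compound 3 is estimated at 120 mL.min-1.g-1, within 40 mL.min-1.g-1 to 350 mL.min-1.g-1.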

Compound 3, intrinsic clearance in microsomes: 27 mL.min-1.g-1
Beside the measured number, compound 3's estimate is 4.4-fold (0.65 log units) above it; the measured number lies below the stated range.
By their numbers in this assay, from the lowest: compound 1; then compound 3; then compound 2.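

This position, on an aromatic carbon of the shared core, clearly matters for clearance: 1,3-dimethyl-1H-pyrazol-4-yl in place of 1-acetylpiperidin-4-yl gives a 7.7-fold lower number from compound 2 to compound 3 (0.88 log units; beyond the scatter) in this assay and takes the number well beyond the usual scatter. Changing the side group alone, with the shared core kept, can therefore move this read-out a long way. No measurement shown here explains why the number falls.

Still open, from the compounds shown here alone, is whether the aromatic ring, its two methyl groups or the loss of the acetyl group drives the drop. Going by these compounds, how an unsubstituted pyrazole or a morpholine would behave at this position also remains unknown.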